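Tolerance of a Sulfonylindole Amide Series on MT4 Cells

This account rests on a few compounds, and the source may have more. Where it says the series, first, only, none or still open, it means among the compounds named here.

Measured so far:
Compound 1, `Cc1cc(C)cc(S(=O)(=O)c2c(C(=O)NC(C)C(=O)NCc3ccco3)[nH]c3ccc(Cl)cc23)c1`: 24200 nM
Compound 2, `Cc1cc(C)cc(S(=O)(=O)c2c(C(=O)NCC(=O)NCc3ccncn3)[nH]c3ccc(Cl)cc23)c1`: > 48800 nM

In an ADME assay on MT4 cells (Homo sapiens) for cytotoxicity, read by MTT assay (a higher number here means that more compound is tolerated, a lower number that less compound is tolerated), compound 1 gives 24200 nM. For compound 2 the reported value is a limit, > 48800 nM, which marks (the limit of > 48800 nM in this assay, at which 1 of the 2 values shown sits). Within the data shown here, the only measured step, an at least 2.0-fold higher number from compound 1 to compound 2 (0.30 log units; that floor lies within the scatter), therefore has a floor but no known size. Compound 3, `Cc1cc(C)cc(S(=O)(=O)c2c(C(=O)NCc3ccc4nc(N)[nH]c4c3)[nH]c3ccc(Cl)cc23)c1`, differs from compound 2 by 2-amino-1H-benzimidazol-6-yl in place of ((pyrimidin-4-yl)methyl)carbamoyl on a saturated chain carbon bound to an amide-type nitrogen. Among the measured compounds shown here, no measured step covers this change, so nothing beyond the floor of the step from compound 1 to compound 2 can be carried over. Compound 3 is expected to stay near the limit of this assay, with an estimated at least 1.2-fold lower number from compound 2 to compound 3 (0.08 log units; that floor lies within the scatter). The estimate for compound 3 is 40000 nM, between 15000 nM and 48800 nM.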

Compound 3, half-maximal cytotoxic concentration: 5890 nM
Compound 3: middle estimate off by 6.8-fold (0.83 log units), on the high side; the measured number lies below the stated range.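

In this assay, among these compounds, 2-amino-1H-benzimidazol-6-yl on the saturated chain carbon bound to an amide-type nitrogen gives the first change beyond the scatter: an at least 8.2-fold lower number from compound 2 to compound 3 (0.91 log units; beyond the scatter). The fall also holds against a compound with a measured number, with a 4.1-fold lower number from compound 1 to compound 3 (0.61 log units; beyond the scatter). The value of compound 2 is a limit, so the full size of its step remains unknown: the limit of > 48800 nM in this assay, at which 1 of the 3 values shown sits.

The compounds shown do not tell whether the fall follows the amine of the entering group or its rings. A benzimidazol-6-yl without the amine, or one on a longer chain, would bear on this.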